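This account rests on a few compounds, and the source may have more. Where it says the series, first, only, none or still open, it means among the compounds named here.

Among the compounds with values here, in a functional assay on the whole organism (Hindlimb, strain albino) with Mus musculus as the target, in the maximal electroshock model, with a stated time of 0.5 h (a lower number here means that less compound is needed, a higher number that more compound is needed for the effect), compound 3 `COc1ccc(/C=C/C(=O)Nc2nc3ccccc3s2)cc1O` gives 495 umol/kg, the highest of the three numbers so far, though the gaps to compound 2 `COc1ccc(/C=C/C(=O)Nc2nc3ccccc3s2)cc1` at 435 umol/kg and to compound 1 `COc1ccc(/C=C/C(=O)Nc2nc3ccc(Cl)cc3s2)cc1O` at 320 umol/kg both lie within the usual scatter. Compound 4 `COc1ccc(/C=C/C(=O)Nc2nc3ccc([N+](=O)[O-])cc3s2)cc1O` differs from compound 3 in one place: nitro in place of hydrogen on an aromatic carbon. The step that bears most on this is a 1.5-fold higher number from compound 1 to compound 3 (0.19 log units; within the scatter), which concerns the same aromatic carbon and stayed within the scatter; a 1.1-fold higher number from compound 2 to compound 3 (0.06 log units; within the scatter) concerns another position and was also within the scatter. Nothing measured here carries a nitro group, so no large shift in either direction is expected in this assay, and compound 4 is estimated at 400 umol/kg, with a range from 180 umol/kg to 850 umol/kg.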

Compound 4, dose for half-maximal effect: 372 umol/kg
Compound 4: the middle estimate sits 1.1-fold (0.03 log units) above what was measured; the measured number falls inside the stated range.
By their numbers in this assay, from the lowest: compounds 1, 4, 2 and 3 (each within the scatter of the next).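

In this assay this aromatic carbon now carries hydrogen, chloro or nitro, and the swaps read as a 1.3-fold lower number from compound 3 to compound 4 (0.12 log units; within the scatter) and a 1.2-fold higher number from compound 1 to compound 4 (0.07 log units; within the scatter). Even nitro, with its three heavy atoms, therefore leaves the number within the scatter of both neighbours, so this position has accepted a larger group without a readable shift. Nothing at hand explains this lack of response. Going by these compounds, whether an amine or a carboxylic acid on this same carbon would also stay within the scatter remains open, as does whether any group here can move the number beyond it.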